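The compounds below may be only part of what the source reports. "The series", "measured", "known", "first", "only" and "open" are said of these compounds alone.

Compound 3 `O=C(NCCO)c1cccc2[nH]c(-c3ccncc3)nc12` gives 498 uM in an ADME assay on Vero cells (Chlorocebus sabaeus) for cytotoxicity; on this read-out lower numbers stand for higher toxicity in this test and higher numbers for lower toxicity in this test. It sits at the low end of the three measured compounds, but compound 1 `O=C(NCCO)c1cccc2[nH]c(-c3ccccn3)nc12` gives 568 uM and compound 2 `O=C(NCCO)c1cccc2[nH]c(-c3cccnc3)nc12` gives 682 uM, and both gaps lie within the usual scatter, so the three cannot be told apart on these numbers. The measured steps only move the nitrogen within the pyridyl ring: a 1.2-fold higher number from compound 1 to compound 2 (0.08 log units; within the scatter), a 1.1-fold lower number from compound 1 to compound 3 (0.06 log units; within the scatter) and a 1.4-fold lower number from compound 2 to compound 3 (0.14 log units; within the scatter). Compound 4 `Cc1csc(NC(=O)c2cccc3[nH]c(-c4ccncc4)nc23)n1` changes a different place: 4-methyl-1,3-thiazol-2-yl in place of 2-hydroxyethyl on an amide-type nitrogen. Among the measured compounds shown here, no measured step touches the amide nitrogen, so those steps give no direct guide; they show only that this read-out has so far moved little. The expected step is a 1.7-fold lower number from compound 3 to compound 4 (0.22 log units; within the scatter), small and uncertain. The estimate for compound 4 is 300 uM, ranging from 60 uM to 800 uM.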

Compound 4, half-maximal toxic concentration: 111 uM
Estimate against measurement, compound 4: 2.7-fold (0.43 log units) above; the range from low to high includes it.
By their numbers in this assay, from the lowest: compound 4; then compounds 3, 1 and 2 (each within the scatter of the next).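

In this assay, among the compounds shown here, swapping 2-hydroxyethyl for 4-methyl-1,3-thiazol-2-yl on the amide-type nitrogen gives a 4.5-fold lower number from compound 3 to compound 4 (0.65 log units; beyond the scatter), the only step here that lies beyond the scatter. Moving the nitrogen within the pyridyl ring left all three earlier compounds within the scatter of each other, so the amide substituent is the first change seen to shift this read-out. Nothing measured here explains the step. With a single replacement shown at this nitrogen, it stays open whether the five-membered aromatic ring, its methyl or the loss of the 2-hydroxyethyl group carries the step. A phenyl ring or a longer chain ending in an amine at the same place would help separate these.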